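A few compounds are considered here, and "the series" means these few. Any claim that something is new, unique, unknown or untested is made for them only; others in the source may bear on it.

Working notes on the series. In a functional assay on DU-145 cells (Homo sapiens) for cytotoxicity, read by trypan blue exclusion, with a stated time of 96 h (a higher number here means a weaker inhibitor, a lower number a stronger inhibitor), compound 3 `COc1cc(OC)c(/C=C/S(=O)(=O)Nc2ccc(OC)c(N)c2)c(OC)c1` gives 5 nM, the lowest number of the three measured. Compound 1 `COc1cc(OC)c(/C=C/S(=O)(=O)Nc2ccc(F)c(N)c2)c(OC)c1` gives 10000 nM and compound 2 `COc1cc(OC)c(/C=C/S(=O)(=O)Nc2cc(N)c(OC)c(N)c2)c(OC)c1` gives 2500 nM; the steps of a 2000-fold lower number from compound 1 to compound 3 (3.30 log units; beyond the scatter) and a 500-fold lower number from compound 2 to compound 3 (2.70 log units; beyond the scatter) are both large, and both change a substituent on the core of compound 3. Compound 4 `COc1cc(OC)c(/C=C/S(=O)(=O)Nc2ccc(OC)c(NC(C(=O)O)c3ccc(F)cc3)c2)c(OC)c1` differs from compound 3 by carboxy(4-fluorophenyl)methyl in place of hydrogen on a nitrogen on an aromatic ring. Going by the values given here, neither measured step alters the amino nitrogen itself, so no step bears directly on this change; the two steps show only that the core of compound 3 responds strongly to substituent changes. A moderate step toward a higher number is therefore expected, a 6.0-fold higher number from compound 3 to compound 4 (0.78 log units; beyond the scatter), with wide uncertainty. Compound 4 is estimated at 30 nM, range 4 nM to 300 nM.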

Compound 4, half-maximal inhibitory concentration: 75 nM
The estimate for compound 4 lay 2.5-fold (0.40 log units) below the measured number; measured number inside the range.
By their numbers in this assay, from the lowest: compound 3; then compound 4; then compound 2; then compound 1.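

Going by these compounds alone, this is the first measured change on the amino nitrogen itself: carboxy(4-fluorophenyl)methyl in place of hydrogen gives a 15-fold higher number from compound 3 to compound 4 (1.18 log units; beyond the scatter) and is a large step. The position still accepts this group of 11 heavy atoms, with compound 4 at 75 nM. Nothing shown gives a reason for the step. 

On these data alone, it remains open which part of the entering group carries the step. A plain benzyl or a carboxymethyl on the same nitrogen would separate the contribution of the 4-fluorophenyl ring from that of the carboxylic acid.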